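This account rests on a few compounds, and the source may have more. Where it says the series, first, only, none or still open, it means among the compounds named here.

Working notes on the series in a functional assay on DLD-1 cells (Homo sapiens) for cytotoxicity, read by resazurin assay, with a stated time of 48 h; on this read-out lower numbers stand for an effect already at smaller amounts and higher numbers for an effect only at larger amounts of compound. Compound 1 `O=C(Nc1ccc(Sc2nc3ccccc3s2)cc1)c1cc(Br)cc(Br)c1O` gives 20000 nM in this assay. Compound 2 `O=S(=O)(Nc1ccc(-c2nc3cc(NS(=O)(=O)c4cccc5ccccc45)ccc3o2)cc1)c1cccc2ccccc12` gives 34000 nM, and compound 3 `O=S(=O)(Nc1ccc(-c2nc3cc(NS(=O)(=O)c4ccccc4Cl)ccc3o2)cc1)c1ccccc1Cl` gives 17000 nM. All three numbers sit within the usual scatter of one another: compound 1 lies nearest to compound 3 and furthest from compound 2, yet neither gap is beyond the scatter, so no order among the three can be stated. Going by the values given here, compounds 2 and 3 rest on a core unlike that of compound 1, and no single-point step joins them to it.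

Compound 4 `O=C(Nc1ccc(Sc2nc3ccccc3s2)cc1)c1cccc(Br)c1O` is not yet measured. It differs from compound 1 by hydrogen in place of bromo on an aromatic carbon; cut one bond further out, 3,5-dibromo-2-hydroxyphenyl becomes 3-bromo-2-hydroxyphenyl. Among the compounds with values here, no measured pair shows what such a change does here, so the expectation rests on compound 1 alone. The step from compound 1 to compound 4 is expected to be a 1.5-fold higher number from compound 1 to compound 4 (0.18 log units; within the scatter), small and toward a higher number or none beyond the scatter. Compound 4 is therefore expected near 30000 nM in this assay, within 12000 nM to 80000 nM, because compound 1 gives 20000 nM and the change is a single heavy atom.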

Compound 4, half-maximal effective concentration: 12000 nM
The estimate for compound 4 lay 2.5-fold (0.40 log units) above the measured number, within the range that was stated.
By their numbers in this assay, from the lowest: compounds 4, 3, 1 and 2 (each within the scatter of the next, the first and the last beyond it).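

In this assay, going by these compounds alone, hydrogen in place of bromo on this aromatic carbon, para to the hydroxy group, gives a 1.7-fold lower number from compound 1 to compound 4 (0.22 log units; within the scatter) and provides the first single-point step. Within this one pair, the change from 3,5-dibromo-2-hydroxyphenyl to 3-bromo-2-hydroxyphenyl shows no effect beyond the scatter, so a bromo group at this position is not needed for a number of this size. Nothing at hand explains the size of this step.

As far as these compounds go, it remains open whether an amine, a methoxy group or a carboxylic acid at this position would shift the number beyond the scatter. Within the data shown here, also open is what the remaining bromo group and the hydroxy group contribute, since no step at either place is available.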